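The source may report more compounds than this note shows. Statements on the series, on what has been measured and on what is new or still open speak of the compounds shown alone.

The measured compounds and their values:

Compound 1, `O=C(O)COc1cccc(NC(=O)c2ccc(Oc3ccccc3)cc2)c1`, in an assay on isolated protein for agonist activity at Bile acid receptor (Homo sapiens), read by TR-FRET, with a stated time of 3 h, in the absence of a further agent (a higher number here means that more compound is needed for the effect, a lower number that less compound is needed), gives > 10000 nM, which is a limit of the assay and not a number.
Compound 2, `CC(Oc1cccc(NC(=O)c2ccc(Oc3ccccc3)cc2)c1)C(=O)O`, in this assay gives > 10000 nM, again a limit and not a number.
Compound 3, `CCCCOc1cccc(C(=O)Nc2cccc(C(=O)O)c2)c1`, in this assay gives 3150 nM.

Between compound 1 and compound 2 the change is methyl in place of hydrogen on a saturated chain carbon bound to a carbonyl carbon and an oxygen on an aromatic ring. The step that the two limits leave unreadable from compound 1 to compound 2 cannot be sized, because of the limit of > 10000 nM in this assay, at which 2 of the 3 values shown sit. Compound 3 stands on a different core from compound 1; the difference between the two cores is not broken down here, and compound 3 is the only one of the three to give a number rather than a limit.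

Compound 4, `CCCCCOc1cccc(C(=O)Nc2cccc(C(=O)O)c2)c1`, has not yet been measured. It differs from compound 3 by methyl in place of hydrogen on a saturated chain carbon, four bonds along the chain from an oxygen on an aromatic ring. This is the same kind of change as that from compound 1 to compound 2, but the place is not the same: there the added carbon sits on a saturated chain carbon bound to a carbonyl carbon and an oxygen on an aromatic ring, here on a saturated chain carbon, four bonds along the chain from an oxygen on an aromatic ring, so the chain reads propyl to butyl. Since the earlier step is unreadable, the expectation rests only on compound 3 and its value 3150 nM, and the step expected is a 1.3-fold lower number from compound 3 to compound 4 (0.10 log units; within the scatter), small and within the usual scatter. Compound 4 is therefore expected to give about 2500 nM in this assay, most likely between 800 nM and 8000 nM.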

Compound 4, half-maximal effective concentration: 2540 nM
Estimate against measurement, compound 4: 1.0-fold (0.01 log units) below; low and high end bracket the measured number.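

On the core of compound 3, methyl in place of hydrogen on a saturated chain carbon, four bonds along the chain from an oxygen on an aromatic ring, gives in this assay a 1.2-fold lower number from compound 3 to compound 4 (0.09 log units; within the scatter), a step within the usual scatter, so this assay does not tell the two compounds apart. Going by these compounds alone, the same kind of change on the core of compound 1, made at a different place, cannot be read, because compound 1 and compound 2 each give a limit and not a number: the limit of > 10000 nM in this assay, at which 2 of the 4 values shown sit. The series therefore shows nothing about whether the change carries from one core to the other, since its one readable step holds for one place on one core and offers no second step to set against it.

The compounds shown leave open whether a longer chain on the oxygen of the core of compound 4, which gives 2540 nM, would stay within the scatter of that value or move beyond it. They also leave open how an amine in place of the carboxylic acid on that core would read in this assay.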